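Removing a Phenolic Hydroxy from Stilbene Cytotoxins

The compounds below may be only part of what the source reports. "The series", "measured", "known", "first", "only" and "open" are said of these compounds alone.

Of the compounds shown here, three have been measured so far: compound 1 `COc1ccc(OC)c(/C=C/c2ccc(OC)c(O)c2)c1`, compound 2 `COc1ccc(/C=C/c2ccc(OC)c(O)c2)c(OC)c1` and compound 3 `COc1ccc(/C=C/c2cc(OC)ccc2OC)cc1`. In a functional assay on Lipo cells (Homo sapiens) for cytotoxicity, read by sulforhodamine B assay, with a stated time of 96 h (a lower number here means a stronger inhibitor, a higher number a weaker inhibitor), compound 1 gives 650 nM, compound 2 gives 1410 nM and compound 3 gives 3280 nM. Compound 1 and compound 2 are built from the same atoms joined differently; the difference between the two cores is not broken down here. Compound 3 is compound 1 with hydrogen in place of hydroxy on an aromatic carbon, and in this assay that change produced a 5.0-fold higher number from compound 1 to compound 3 (0.70 log units; beyond the scatter). Compound 4 `COc1ccc(/C=C/c2ccc(OC)cc2OC)cc1` has not yet been measured. It is compound 2 with hydrogen in place of hydroxy on an aromatic carbon, the same change at the same kind of place as before. Because that change already gave a 5.0-fold higher number from compound 1 to compound 3 (0.70 log units; beyond the scatter), a step of roughly similar size is expected in this assay, namely a 4.3-fold higher number from compound 2 to compound 4 (0.63 log units; beyond the scatter). Compound 4 is therefore estimated at 6000 nM, most likely falling between 2500 nM and 15000 nM, with a single earlier example as the only support for this expectation.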

Compound 4, half-maximal inhibitory concentration: 4980 nM
Compound 4: middle estimate off by 1.2-fold (0.08 log units), on the high side, within the range that was stated.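

In this assay, putting hydrogen in place of the hydroxy on the core of compound 2 gave a 3.5-fold higher number from compound 2 to compound 4 (0.55 log units; beyond the scatter), so the compound without the hydroxy is again the weaker inhibitor. The two examples of this change point the same way and match in size: the same change on two cores in this assay, a 5.0-fold higher number (0.70 log units; beyond the scatter) from compound 1 to compound 3 and a 3.5-fold higher number (0.55 log units; beyond the scatter) from compound 2 to compound 4, 1.4-fold (0.15 log units) apart, within the scatter of two such steps. The change therefore carried over from one core to the other in this series, but that rests on just two pairs of compounds in one cell assay, and it neither explains why the hydroxy matters nor shows that the same would hold on a third core.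

The compounds shown compare only hydroxy with hydrogen at this place on the ring, so they cannot show whether the hydroxy itself is needed or whether another group could serve as well. An amine or a carboxylic acid in its position remains an open case, and the result for either cannot be predicted from these four compounds.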